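This account rests on a few compounds, and the source may have more. Where it says the series, first, only, none or still open, it means among the compounds named here.

Measured in a functional assay on THP-1 cells (Homo sapiens) for cytotoxicity, read by MTT assay, with a stated time of 24 h (on this read-out lower numbers stand for stronger inhibition and higher numbers for weaker inhibition), as follows:
Compound 1 `CN1C/C(=C\c2ccc(C(F)(F)F)cc2)C(=O)/C(=C/c2ccccc2F)C1` gives 5930 nM
Compound 2 `CN1C/C(=C\c2ccc(F)cc2)C(=O)/C(=C/c2ccc(C#N)cc2)C1` gives 5030 nM

Among the compounds with values here, these are the only two numbers so far. Compound 2 at 5030 nM lies within the usual scatter of compound 1 at 5930 nM and no order can be drawn between them.

Next is compound 3 `CN1C/C(=C\c2ccc(C#N)cc2)C(=O)/C(=C/c2ccc(Cl)cc2Cl)C1`, which has 2,4-dichlorophenyl in place of 4-fluorophenyl on a double-bonded chain carbon bound to a double-bonded ring carbon, relative to compound 2 (2,4-dichlorophenyl in place of 4-fluorophenyl on a double-bonded chain carbon bound to a double-bonded ring carbon). Within the data shown here, no measured pair differs in one place only, so the data give no direct size for such a step in this assay and the expectation remains loose. With compound 1 at 5930 nM and compound 2 at 5030 nM close together, a large move is not expected. A small shift toward a lower number is the working expectation, and it may not clear the scatter. The estimated step is a 1.3-fold lower number from compound 2 to compound 3 (0.12 log units; within the scatter) and carries little confidence. For compound 3 the expected value is 3800 nM with 1600 nM to 8500 nM as the estimated range.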

Compound 3, half-maximal inhibitory concentration: 1910 nM
For compound 3 the middle estimate is 2.0-fold (0.30 log units) above the measured one, and the stated range covers the measured number.
By their numbers in this assay, from the lowest: compound 3; then compounds 2 and 1 (each within the scatter of the next).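

In this assay, within the data shown here, 2,4-dichlorophenyl in place of 4-fluorophenyl on a double-bonded chain carbon bound to a double-bonded ring carbon gives a 2.6-fold lower number from compound 2 to compound 3 (0.42 log units; beyond the scatter), the first step read between compounds that differ in one place. The change at this position therefore moves the cytotoxicity read-out beyond the usual scatter, something the two earlier values could not show, as they lay within the scatter of each other. The step is modest and rests on a single pair, and no measurement at hand bears on what lies behind it.

Going by these compounds, whether the lower number needs both chlorine atoms or follows from one of them alone remains open, and a 4-chlorophenyl or 2-chlorophenyl group in this place would separate the two cases. Also open, on these data alone, is whether the trend is confined to halogen-bearing phenyl groups, or whether a phenyl group carrying an amine or a carboxylic acid in the same place would shift the value in the same direction.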